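A few compounds are considered here, and "the series" means these few. Any claim that something is new, unique, unknown or untested is made for them only; others in the source may bear on it.

Compound 1 `Cn1cc(C2=C(c3nn(CCCn4cccc4)c4ncccc34)C(=O)NC2=O)c2ccccc21` gives > 100000 nM in a functional assay on A549 cells (Homo sapiens) for antiproliferative activity, read by MTT assay, with a stated time of 48 h (on this read-out lower numbers stand for stronger inhibition and higher numbers for weaker inhibition), which is a limit of the assay and not a number. Compound 2 `Cn1cc(C2=C(c3nn(CCCn4ccnc4)c4ncccc34)C(=O)NC2=O)c2ccccc21` gives > 100000 nM in this assay, again only a limit. Compound 2 therefore has no number of its own, and the evidence so far is the limit of > 100000 nM in this assay, at which 2 of the 2 values shown sit. Compound 3 `CN1CCN(CCCn2nc(C3=C(c4cn(C)c5ccccc45)C(=O)NC3=O)c3cccnc32)CC1` keeps the shared core and changes one group, (4-methylpiperazin-1-yl in place of 1H-imidazol-1-yl on a saturated chain carbon, three bonds along the chain from an aromatic nitrogen), placing 4-methylpiperazin-1-yl where 1H-imidazol-1-yl stood, on a saturated chain carbon, three bonds along the chain from an aromatic nitrogen. Among the compounds with values here, the only measured step at this place, a step that the two limits leave unreadable from compound 1 to compound 2, offers no size to carry over. Any readable change is expected toward stronger inhibition, the one direction that the limit of compound 2 leaves open. The expected step is an at least 1.6-fold lower number from compound 2 to compound 3 (0.22 log units; that floor lies within the scatter), a loose estimate. For compound 3 the estimated value is 60000 nM, with an expected range from 10000 nM to 200000 nM.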

Compound 3, half-maximal inhibitory concentration: > 100000 nM
Compound 3: only a limit was reported (the forecaster's own chance of this, stated with the estimate: 50%); at least 1.6-fold (0.22 log units) between middle value and limit.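

Compound 3, like compound 1 and compound 2, gives only a limit of the assay, so no step among these compounds can be read: the limit of > 100000 nM in this assay, at which 3 of the 3 values shown sit. The compounds shown leave open whether 1H-pyrrol-1-yl, 1H-imidazol-1-yl or 4-methylpiperazin-1-yl at this place changes inhibition in this assay at all.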